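Shifting the Methoxy Group on the Pendant Phenyl Ring

The source may hold more compounds than are shown below. What is called first, only, known or untested is meant among the compounds shown, and "the series" means these compounds.

Measured compounds:
compound 1, `CCCCCCCCS(=O)(=O)Nc1cc(-c2cccc(Cl)c2)ccc1C(=O)O`: 13800 nM
compound 2, `CCCCCCCCS(=O)(=O)Nc1cc(-c2ccc(CCCC)cc2)ccc1C(=O)O`: 15700 nM
compound 3, `CCCCCCCCS(=O)(=O)Nc1cc(-c2ccccc2OC)ccc1C(=O)O`: 16100 nM

In an assay on mitochondria (strain BALB/c) for inhibition of glycerol-3-phosphate acyltransferase 1, mitochondrial (Mus musculus), read by scintillation counting, with a stated time of 10 min (a lower number here means a stronger inhibitor, a higher number a weaker inhibitor), compound 3 gives the highest of the three numbers, yet its steps to the other two are within the scatter, so no order can be read. The measured steps are a 1.1-fold higher number from compound 1 to compound 2 (0.06 log units; within the scatter), a 1.2-fold higher number from compound 1 to compound 3 (0.07 log units; within the scatter) and a 1.0-fold higher number from compound 2 to compound 3 (0.01 log units; within the scatter); each swaps the whole pendant phenyl group without shifting the numbers beyond the scatter. Compound 4, `CCCCCCCCS(=O)(=O)Nc1cc(-c2ccc(OC)cc2)ccc1C(=O)O`, differs from compound 3 only in the position of the methoxy group: 4-methoxyphenyl in place of 2-methoxyphenyl on an aromatic carbon. Among the compounds with values here, no measured step moves a group around the pendant ring, so these steps bear only loosely; since all of them were flat, compound 4 is expected to show a 1.0-fold lower number from compound 3 to compound 4 (0.00 log units; within the scatter). Compound 4 is estimated at 16000 nM, within 8000 nM to 32000 nM.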

Compound 4, half-maximal inhibitory concentration: 13300 nM
Compound 4: middle estimate off by 1.2-fold (0.08 log units), on the high side; the range from low to high includes it.
By their numbers in this assay, from the lowest: compounds 4, 1, 2 and 3 (each within the scatter of the next).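

Moving the methoxy group around the pendant ring gives the first positional comparison, and in this assay it produces a 1.2-fold lower number from compound 3 to compound 4 (0.08 log units; within the scatter), so 2-methoxyphenyl and 4-methoxyphenyl cannot be told apart at this place. Other changes to the pendant group are just as flat: methoxy in place of butyl gives a 1.2-fold lower number from compound 2 to compound 4 (0.07 log units; within the scatter), and 4-methoxyphenyl in place of 3-chlorophenyl gives a 1.0-fold lower number from compound 1 to compound 4 (0.02 log units; within the scatter). No measurement here offers an explanation for these results. Still open, going by these compounds, is whether an amine or a carboxylic acid on the pendant ring would move the number beyond the scatter.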